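The compounds below may be only part of what the source reports. "The series", "measured", "known", "first", "only" and "open" are said of these compounds alone.

Measured in a functional assay (Mus musculus, strain Balb/c) for inhibition, read by ELISA, with a stated time of 72 h; a lower number here means a stronger inhibitor, a higher number a weaker inhibitor:
compound 1 `COc1ccc(C(/C=C/c2ccc(Cl)cc2)=N/O)cc1` — 11500 nM
compound 2 `COc1ccc(C(/C=C/c2ccc(F)cc2)=N/O)cc1` — 11000 nM
compound 3 `COc1ccc(C(/C=C/c2cccs2)=N/O)cc1` — 8490 nM

Compound 3 gives the lowest of the three numbers, yet its distances to compound 2 and to compound 1 are both within the scatter, so the three compounds are not separated in this assay. Compound 4 `COc1ccc(C(/C=C/c2ccccc2)=N/O)cc1` differs from compound 3 by phenyl in place of thiophen-2-yl on a double-bonded chain carbon bound to a double-bonded chain carbon. Among the compounds with values here, the only measured step, a 1.0-fold lower number from compound 1 to compound 2 (0.02 log units; within the scatter), exchanges one substituent on the aromatic ring at that end of the chain and stays within the scatter; no measured step exchanges that ring itself. On this basis no step beyond the scatter is expected in this assay, and the expected step is a 1.1-fold higher number from compound 3 to compound 4 (0.05 log units; within the scatter). For compound 4 the estimate is 9500 nM, ranging from 5000 nM to 18000 nM.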

Compound 4, half-maximal inhibitory concentration: 11800 nM
The estimate for compound 4 lay 1.2-fold (0.09 log units) below the measured number; low and high end bracket the measured number.
By their numbers in this assay, from the lowest: compounds 3, 2, 1 and 4 (each within the scatter of the next).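

In this assay, replacing the ring itself at this place leaves the number within the scatter (a 1.4-fold higher number from compound 3 to compound 4 (0.14 log units; within the scatter)). Removing the ring substituent does the same, whether fluoro (a 1.1-fold higher number from compound 2 to compound 4 (0.03 log units; within the scatter)) or chloro (a 1.0-fold higher number from compound 1 to compound 4 (0.01 log units; within the scatter)), so phenyl is not separated from thiophen-2-yl or from either halogenated phenyl. No measured evidence bears on this flat result.

Still open, on these data alone, is whether an amine or a carboxylic acid on this ring, or cyclohexyl in place of it, would give a step beyond the scatter. All four compounds carry the shared core unchanged, so they say nothing about its role.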